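Bromo in place of methoxy on compound 2

The source may report more compounds than this note shows. Statements on the series, on what has been measured and on what is new or still open speak of the compounds shown alone.

In a functional assay on MCF7 cells (Homo sapiens) for inhibition, read by sulforhodamine B assay, with a stated time of 48 h (a lower number here means a stronger inhibitor of growth, a higher number a weaker inhibitor of growth), compound 1 (`S=C(N/N=C/c1cccs1)Nc1ccccc1`) gives 94600 nM as its measured value. For compound 2 (`COc1ccc(NC(=S)N/N=C/c2cccs2)cc1`) there is only a limit, > 100000 nM and not a number. Compound 3 (`S=C(N/N=C/c1cccs1)Nc1ccc(Br)cc1`) carries bromo in place of methoxy on an aromatic carbon, para to a large group: bromo in place of methoxy on an aromatic carbon and no other change. Among the measured compounds shown here, the one measured step, an at least 1.0-fold higher number from compound 1 to compound 2 (0.02 log units; that floor lies within the scatter) with methoxy in place of hydrogen on an aromatic carbon, shows nothing beyond the scatter, so no step beyond the scatter is expected here. The estimated step is an at least 1.2-fold lower number from compound 2 to compound 3 (0.09 log units; that floor lies within the scatter) in this assay with neither direction favoured. For compound 3 the estimated value is 80000 nM with an expected range from 30000 nM to 130000 nM in this estimate.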

Compound 3, concentration for 50% growth inhibition: < 740 nM
Compound 3: no number, only a limit; the forecaster's own chance of this, stated with the estimate: 35%; middle value at least 100-fold (2.03 log units) away from the limit.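

On the aromatic carbon para to a large group, the earlier change from hydrogen to methoxy showed nothing beyond the scatter in this assay, so this position could have seemed indifferent to what sits there. Bromo shows otherwise, with an at least 130-fold lower number from compound 2 to compound 3 (2.13 log units; beyond the scatter) and, set against hydrogen, an at least 120-fold lower number from compound 1 to compound 3 (2.10 log units; beyond the scatter). Both steps are floors, since compound 3 has only a limit: the limit of < 740 nM in this assay, at which 1 of the 3 values shown sits.

From the compounds shown here alone, whether bromo is unusual here stays open; chloro or an amine on the same carbon would test that. How bromo behaves on another carbon of this ring is also unknown.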